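A Hydroxymethyl Swap Tested Against an Assay Floor

The source may report more compounds than this note shows. Statements on the series, on what has been measured and on what is new or still open speak of the compounds shown alone.

Compound 1 `O=C(NO)c1cccc(-c2cn([C@H]3C[C@H](CO)N(CCCc4ccccc4)C3)nn2)c1` gives < 10% in an assay on Sf9 cells for inhibition of histone deacetylase 11 (Homo sapiens), read by fluorescence, tested at 0.5 uM (a higher number here means more inhibition at the concentration tested (going by the name of the read-out), a lower number less inhibition), a limit of the assay.
Compound 2 `O=C(NO)c1cccc(-c2cn([C@H]3C[C@H](C(=O)O)N(CCCc4ccccc4)C3)nn2)c1` gives < 10% in this assay, also a limit.
Compound 3 `O=C(NO)c1cccc(-c2cn([C@H]3C[C@H](C(=O)O)N(Cc4ccccc4)C3)nn2)c1` gives < 10% in this assay, again a limit.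

Compound 4 `O=C(NO)c1cccc(-c2cn([C@H]3C[C@H](CO)N(Cc4ccccc4)C3)nn2)c1` has not yet been measured. It differs from compound 3 by hydroxymethyl in place of carboxy on a saturated ring carbon. The same kind of change separates compound 2 from compound 1, (hydroxymethyl in place of carboxy on a saturated ring carbon), the difference around the place being that the ring atom there bears a 3-phenylpropyl group rather than a benzyl group. The cores of compound 2 and compound 3 differ by phenyl in place of phenethyl on a saturated chain carbon bound to an amine nitrogen in a ring. Because every measured value sits at the limit of < 10% in this assay, at which 3 of the 3 values shown sit, the steps a step that the two limits leave unreadable from compound 2 to compound 1 and a step that the two limits leave unreadable from compound 2 to compound 3 cannot be sized. The step to compound 4 is expected to be a step that the limit leaves unreadable from compound 3 to compound 4, resting on the observation that all three measured values sit at the limit of < 10% in this assay, at which 3 of the 3 values shown sit. Compound 4 is therefore estimated at 3%, with a range from 0% to 12%.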

Compound 4, a percentage reported as inhibition, at one concentration (the size of the read-out at that concentration, not a potency): < 10%
Compound 4 ended at the assay's limit (the forecaster's own chance of this, stated with the estimate: 90%); the middle value is on the limit's open side.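

Neither new step, from compound 3 to compound 4 or from compound 1 to compound 4, can be read, because both ends of each step are limits: the limit of < 10% in this assay, at which 4 of the 4 values shown sit.

The compounds shown leave open whether hydroxymethyl or carboxy, or a benzyl or 3-phenylpropyl group, makes any difference to inhibition.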